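Trimming Benzyl to Methyl at the Selenium Position

A few compounds are considered here, and "the series" means these few. Any claim that something is new, unique, unknown or untested is made for them only; others in the source may bear on it.

Of the compounds shown here, two have been measured in an ADME assay on MCF-10A cells (Homo sapiens) for cytotoxicity, read by MTT assay, with a stated time of 72 h; on this read-out lower numbers stand for stronger inhibition of growth and higher numbers for weaker inhibition of growth. Compound 1 `CS/C(=N\C(=O)c1sccc1Cl)NC(=O)c1sccc1Cl` gives 90 nM, while compound 2 `O=C(/N=C(/NC(=O)c1cc(-c2ccccc2)nc2ccccc12)[Se]Cc1ccccc1)c1cc(-c2ccccc2)nc2ccccc12` gives 8460 nM, the higher of the two numbers and well beyond the scatter from compound 1. Compound 3 `C[Se]/C(=N\C(=O)c1cc(-c2ccccc2)nc2ccccc12)NC(=O)c1cc(-c2ccccc2)nc2ccccc12` keeps the core of compound 2 and differs by hydrogen in place of phenyl on a saturated chain carbon bound to a selenium atom. Among the measured compounds shown here, with no directly comparable pair available, only a modest step toward a lower number is expected for compound 3 in this assay, and the estimate a 2.1-fold lower number from compound 2 to compound 3 (0.33 log units; beyond the scatter) places compound 3 at 4000 nM, within 800 nM to 20000 nM.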

Compound 3, concentration for 50% growth inhibition: 710 nM
For compound 3 the middle estimate is 5.6-fold (0.75 log units) above the measured one; the measured number lies below the stated range.
By their numbers in this assay, from the lowest: compound 1; then compound 3; then compound 2.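

In this assay the change from benzyl to methyl, on a saturated chain carbon bound to a selenium atom, gives a 12-fold lower number from compound 2 to compound 3 (1.08 log units; beyond the scatter) and so shows that the number responds strongly to this position. Among the compounds shown here, the earlier compounds offered no pair differing in one place, so this is the first single change that can be read. Nothing available explains the size of this step.

As far as these compounds go, whether an ethyl group, a longer chain or an amine at this position would move the number further remains open. From the compounds shown here alone, whether the step would carry over to another core also remains open.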